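Compound 3 as a methyl-shifted isomer of compound 2

The source may hold more compounds than are shown below. What is called first, only, known or untested is meant among the compounds shown, and "the series" means these compounds.

Measured in a functional assay on MCF7 cells (Homo sapiens) for cytotoxicity, read by CellTiter-Glo, with a stated time of 5 days; a lower number here means a stronger inhibitor, a higher number a weaker inhibitor:
- compound 1 `CC/C(=C(/c1ccc(/C=C/C(=O)O)cc1)c1ccc2[nH]ncc2c1)c1ccccc1S(C)(=O)=O`: 70 nM
- compound 2 `CC/C(=C(/c1ccc(/C=C/C(=O)O)cc1)c1ccc2[nH]ncc2c1)c1cccnc1C`: 200 nM

Compound 2 carries the higher of the two numbers. Compound 3 `CC/C(=C(/c1ccc(/C=C/C(=O)O)cc1)c1ccc2[nH]ncc2c1)c1cnccc1C` has 4-methylpyridin-3-yl in place of 2-methylpyridin-3-yl on a double-bonded chain carbon bound to a double-bonded chain carbon and a saturated chain carbon. Within the data shown here, the only measured step, a 2.9-fold higher number from compound 1 to compound 2 (0.46 log units; beyond the scatter), is modest and involves a different pair of groups, so it bears only indirectly. Among the measured compounds shown here, no measured step compares the two groups exchanged here. In this assay the expected change is a 1.3-fold lower number from compound 2 to compound 3 (0.10 log units; within the scatter), with no step beyond the scatter anticipated and no direction supported. For compound 3 the estimated value is 160 nM, with an expected range of 60 nM to 420 nM.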

Compound 3, half-maximal inhibitory concentration: 150 nM
Estimate against measurement, compound 3: 1.1-fold (0.03 log units) above; low and high end bracket the measured number.
By their numbers in this assay, from the lowest: compound 1; then compounds 3 and 2 (each within the scatter of the next).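

In this assay, this position on the double-bonded chain carbon accepts the shift from 2-methylpyridin-3-yl to 4-methylpyridin-3-yl, with a 1.3-fold lower number from compound 2 to compound 3 (0.12 log units; within the scatter), so the place of the methyl does not separate these two isomers. Replacing 2-(methylsulfonyl)phenyl with 4-methylpyridin-3-yl gives a 2.1-fold higher number from compound 1 to compound 3 (0.33 log units; beyond the scatter), which leaves both isomers beyond the scatter from compound 1. Nothing available gives a cause for either step.

Still open, going by these compounds, is whether a pyridin-3-yl group carrying methylsulfonyl, or an amine instead of the methyl, would match compound 1 at this position.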